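Shortening an Alkylamine Chain: Expected Vero Cell Tolerance

The source may report more compounds than this note shows. Statements on the series, on what has been measured and on what is new or still open speak of the compounds shown alone.

Results in an ADME assay on Vero cells (Chlorocebus sabaeus) for cytotoxicity, read by fluorescence and resazurin assay, with a stated time of 72 h (a higher number here means that more compound is tolerated, a lower number that less compound is tolerated), so far:
Compound 1 `Cc1ccc(NCC(O)COc2cc(=O)oc3ccccc23)cc1` gives > 100000 nM, a limit of the assay.
Compound 2 `O=C(O)CCCNCC(O)COc1cc(=O)oc2ccccc12` gives "not determined" (no result reported).
Compound 3 `CCCCCCCC/C=C/CCCCCCCCNCC(O)COc1cc(=O)oc2ccccc12` gives > 100000 nM, a limit of the assay.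

Compound 3 therefore stands at the edge of what this assay can report, together with compound 1, as the limit of > 100000 nM in this assay, at which 2 of the 3 values shown sit, shows; no number separates the two. Compound 4 `CCCCCCCCCCCCNCC(O)COc1cc(=O)oc2ccccc12` differs from compound 3 by a group of 4 heavy atoms (4 carbon; no ring) in place of a group of 10 heavy atoms (10 carbon; no ring), on a saturated chain carbon, eight bonds along the chain from an amine nitrogen. Going by the values given here, with both neighbouring results sitting at the limit and no measured step to lean on, no change beyond the usual scatter is expected, that is a step of a number no higher from compound 3 to compound 4 (the limit leaves the size open). Compound 4 is accordingly estimated at 100000 nM, with a range from 40000 nM to 300000 nM, and most likely again only a limit will be reported.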

Compound 4, half-maximal cytotoxic concentration: > 100000 nM
Compound 4: no number, only a limit (the forecaster's own chance of this, stated with the estimate: 80%); the middle value lies on the limit itself.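

Compound 3 and compound 4 both give only a limit, so no step between them can be read: the limit of > 100000 nM in this assay, at which 3 of the 4 values shown sit.

The compounds shown leave open whether any chain length here reaches a measurable cytotoxic concentration in this assay.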